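The source may report more compounds than this note shows. Statements on the series, on what has been measured and on what is new or still open speak of the compounds shown alone.

The series shares one core, seen in compound 1 `COc1cc(C(=O)c2cn(-c3ccccc3)cc2-c2ccc(N)cc2)cc(OC)c1OC`, which in a functional assay on MCF7 cells (Homo sapiens) for cytotoxicity, read by MTT assay, with a stated time of 96 h (a higher number here means a weaker inhibitor, a lower number a stronger inhibitor), gives 9 nM. Within the data shown here, compound 1 stands lowest of the three numbers measured so far. Compound 2 `COc1cc(C(=O)c2cn(-c3ccccc3)cc2-c2ccc([N+](=O)[O-])cc2)cc(OC)c1OC` gives 590 nM in this assay, and compound 3 `COc1ccc(-c2cn(-c3ccccc3)cc2C(=O)c2cc(OC)c(OC)c(OC)c2)cc1` gives 70 nM. The steps separating them are a 66-fold higher number from compound 1 to compound 2 (1.82 log units; beyond the scatter) and a 7.8-fold higher number from compound 1 to compound 3 (0.89 log units; beyond the scatter), with an 8.4-fold lower number from compound 2 to compound 3 (0.93 log units; beyond the scatter) between the other two; all three concern the group on the ring that carries the amino in compound 1, and in each pair the compound with the amino has the lower number.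

Compound 4 `COc1cc(C(=O)c2cn(-c3ccc(N)cc3)cc2-c2ccc(N)cc2)cc(OC)c1OC` differs from compound 1 in another place: amino in place of hydrogen on an aromatic carbon. Among the measured compounds shown here, no measured step touches the ring that carries this change, so none bears on it directly; the only guide is that the amino already present in compound 1 goes with the lowest number. A second amino on the other ring is expected to leave the number near that of compound 1, a shift in either direction that may stay within the scatter or just exceed it. Compound 4 is therefore estimated at 15 nM, with a range of 4 nM to 60 nM, which means the expected step of a 1.7-fold higher number from compound 1 to compound 4 (0.22 log units; within the scatter).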

Compound 4, half-maximal inhibitory concentration: 15 nM
For compound 4 middle estimate and measured number coincide at the digits printed; the range from low to high includes it.
By their numbers in this assay, from the lowest: compounds 1 and 4 (each within the scatter of the next); then compound 3; then compound 2.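

In this assay, among these compounds, the change from phenyl to 4-aminophenyl is a 1.7-fold higher number from compound 1 to compound 4 (0.22 log units; within the scatter), the first reading on this ring, as the steps among compounds 1, 2 and 3 all concern the other ring. An amino para to a large group therefore leaves compound 4 indistinguishable from compound 1, so this place accepts the added group without a measurable loss. No measurement at hand offers a reason for this result.

Still open, as far as these compounds go, is how other groups at this place would read, such as a hydroxyl, a dimethylamino or a carboxylic acid. Also open, from the compounds shown here alone, is whether 4-aminophenyl here would give the same reading with methoxy or nitro in place of the amino on the other ring.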